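Chloro to Trifluoromethyl on a Shared Core

The source may report more compounds than this note shows. Statements on the series, on what has been measured and on what is new or still open speak of the compounds shown alone.

Compound 1 `CC(C)(C)c1ccc(C(=O)/C=C/c2ccncc2)cc1`: 47000 nM in a functional assay with Rattus norvegicus as the target; on this read-out higher numbers stand for weaker inhibition and lower numbers for stronger inhibition
Compound 2 `O=C(/C=C/c1ccncc1)c1ccc(Cl)cc1`: 60000 nM in this assay

Compound 2 holds the higher of the two numbers, yet the step of a 1.3-fold higher number from compound 1 to compound 2 (0.11 log units; within the scatter) is within the scatter, so the two compounds cannot be told apart. Compound 3 `O=C(/C=C/c1ccncc1)c1ccc(C(F)(F)F)cc1` differs from compound 2 by trifluoromethyl in place of chloro on an aromatic carbon. Among the compounds with values here, the only measured step, a 1.3-fold higher number from compound 1 to compound 2 (0.11 log units; within the scatter), concerns another exchange on an aromatic carbon and stayed within the scatter; no measured step compares trifluoromethyl with chloro. A step of a 1.1-fold lower number from compound 2 to compound 3 (0.04 log units; within the scatter) is therefore expected, nothing beyond the scatter. Compound 3 is estimated at 55000 nM, between 20000 nM and 150000 nM.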

Compound 3, half-maximal inhibitory concentration: 204000 nM
Compound 3: middle estimate off by 3.7-fold (0.57 log units), on the low side; the whole stated range lies below it.
By their numbers in this assay, from the lowest: compounds 1 and 2 (each within the scatter of the next); then compound 3.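

This position on the shared core does respond to its group: in this assay the step of a 3.4-fold higher number from compound 2 to compound 3 (0.53 log units; beyond the scatter) lies beyond the scatter and points to weaker inhibition. The step of a 4.3-fold higher number from compound 1 to compound 3 (0.64 log units; beyond the scatter) also lies beyond the scatter, so trifluoromethyl stands apart from both chloro and tert-butyl, which could not be told apart from each other. Nothing available explains this difference.

Still open, from the compounds shown here alone, is how an amine or a carboxylic acid at this place would compare. Going by these compounds, it is also open whether any group here could give clearly stronger inhibition than chloro and tert-butyl.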